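Replacing the Amide Arm on the Triazole of Compound 1

The compounds below may be only part of what the source reports. "The series", "measured", "known", "first", "only" and "open" are said of these compounds alone.

The measured compounds:
compound 1 `CCOC(=O)C1=Cc2ccccc2OC1(OCc1cn(CC(=O)Nc2ccc(C)cc2)nn1)C(F)(F)F` gives > 150000 nM
compound 2 `COc1ccc(-c2cc(COC3(C(F)(F)F)Oc4ccccc4C=C3C(=O)O)on2)cc1` gives 35200 nM
compound 3 `CCOC(=O)C1=Cc2ccccc2OC1(OCc1cc(-c2ccc(F)cc2)no1)C(F)(F)F` gives 48200 nM

The three compounds were tested in a functional assay on MCF7 cells (Homo sapiens) for inhibition, read by MTT assay, with a stated time of 24 h; on this read-out lower numbers stand for stronger inhibition and higher numbers for weaker inhibition. Compound 1 stands apart from the other two in that its result is a limit of the assay and not a number (the limit of > 150000 nM in this assay, at which 1 of the 3 values shown sits). Compound 2 and compound 3 carry an aryl group on a different five-membered ring from that of compound 1. Compound 2 reaches 35200 nM and compound 3 reaches 48200 nM, values that lie within the scatter of each other.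

The unmeasured compound 4 `CCOC(=O)C1=Cc2ccccc2OC1(OCc1cn(-c2cccc(OC)c2)nn1)C(F)(F)F` shares the core of compound 1 and differs from it in one place: 3-methoxyphenyl in place of ((4-methylphenyl)carbamoyl)methyl on an aromatic nitrogen. The group that enters is a plain aryl, without the amide hydrogen of the group that leaves, which puts compound 4 closer in make-up to compound 2 and compound 3 than to compound 1.

Among the compounds with values here, no step between measured compounds is available to guide the size of this change. The account therefore expects that compound 4 moves from the limit toward the region of compound 2 and compound 3, a step of an at least 1.8-fold lower number from compound 1 to compound 4 (0.27 log units; that floor lies within the scatter), while it remains possible that compound 4 also returns only a limit. For compound 4 the estimated value in this assay is 80000 nM, with a range from 30000 nM to 200000 nM.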

Compound 4, half-maximal inhibitory concentration: > 150000 nM
Compound 4: no number, only a limit; the forecaster's own chance of this, stated with the estimate: 40%; at least 1.8-fold (0.27 log units) between middle value and limit.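

Within the data shown here, compound 4 gives a limit and not a number, as compound 1 does, so no step from compound 1 to compound 4 can be read: the limit of > 150000 nM in this assay, at which 2 of the 4 values shown sit.

The compounds shown leave open whether 3-methoxyphenyl in place of ((4-methylphenyl)carbamoyl)methyl on the aromatic nitrogen changes the inhibition at all, and if so, in which direction.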